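The compounds below may be only part of what the source reports. "The series", "measured", "known", "first", "only" and "open" are said of these compounds alone.

Among the measured compounds shown here, compound 3 `O=C(/C(=C\c1ccc[nH]1)SCc1ccc(Cl)cc1)c1ccc(Cl)cc1` is one of three compounds measured in a functional assay on DU-145 cells (Homo sapiens) for inhibition, read by trypan blue exclusion, with a stated time of 96 h; on this read-out lower numbers stand for stronger inhibition of growth and higher numbers for weaker inhibition of growth. There compound 3 gives 10000 nM, level with compound 1 `COc1ccc(/C=C(/SCc2ccc(Cl)cc2)C(=O)c2ccc(Cl)cc2)cc1`, which gives 10000 nM; both stand lowest of the three. Compound 2 `Cc1ccc(S/C(=C/c2cc(C)cc(C)c2)C(=O)c2ccc(Cl)cc2)cc1` gives 50000 nM, a higher number that lies beyond the scatter.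

Compound 4 `Cc1cc(C)cc(/C=C(/SCc2ccc(Cl)cc2)C(=O)c2ccc(Cl)cc2)c1` differs from compound 3 by 3,5-dimethylphenyl in place of 1H-pyrrol-2-yl on a double-bonded chain carbon bound to a double-bonded chain carbon. For the measured compounds named here, the only step at this place among the measured compounds is the move from compound 1 to compound 3, with no change at the digits printed from compound 1 to compound 3 (within the scatter). Compound 2 also carries a 3,5-dimethylphenyl, but differs from compound 4 elsewhere as well, so it gives only a hint. The step is therefore expected to be small, with a slight lean toward a higher number, a 1.5-fold higher number from compound 3 to compound 4 (0.18 log units; within the scatter). Compound 4 is expected to give about 15000 nM, in the range 5000 nM to 50000 nM.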

Compound 4, concentration for 50% growth inhibition: 10000 nM
Compound 4: the middle estimate sits 1.5-fold (0.18 log units) above what was measured; the measured number falls inside the stated range.
By their numbers in this assay, from the lowest: compounds 1, 3 and 4 (each within the scatter of the next); then compound 2.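

In this assay, the double-bonded chain carbon accepts 3,5-dimethylphenyl with no change at the digits printed from compound 3 to compound 4 (within the scatter) and with no change at the digits printed from compound 1 to compound 4 (within the scatter), so the one hydrogen-bond donor of 1H-pyrrol-2-yl is not required there. On the sulfur, the group does matter: 4-chlorobenzyl in place of 4-methylphenyl gives a 5.0-fold lower number from compound 2 to compound 4 (0.70 log units; beyond the scatter) and so accounts for the gap to compound 2.

On these data alone, whether an amine or a carboxylic acid on that chain carbon, or a longer chain on the sulfur, would shift the number remains open. Nothing available explains why these changes act as they do.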